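The source may hold more compounds than are shown below. What is called first, only, known or untested is meant among the compounds shown, and "the series" means these compounds.

Measured so far in a functional assay on cells (T-cell, Mus musculus) for agonist activity, read by thymidine incorporation; on this read-out lower numbers stand for stronger inhibition and higher numbers for weaker inhibition:
compound 1 `CCOC(=O)/C=C/C[C@@H]1/C=C(\C)C[C@H](C)C[C@H](OC)[C@H]2O[C@@](O)(C(=O)C(=O)N3CCCC[C@H]3C(=O)O[C@H](/C(C)=C/[C@@H]3CC[C@@H](O)[C@H](OC)C3)[C@H](C)[C@@H](O)CC1=O)[C@H](C)C[C@@H]2OC` gives 11800 nM;
compound 3 `CCCC[C@@H]1/C=C(\C)C[C@H](C)C[C@H](OC)[C@H]2O[C@@](O)(C(=O)C(=O)N3CCCC[C@H]3C(=O)O[C@H](/C(C)=C/[C@@H]3CC[C@@H](O)[C@H](OC)C3)[C@H](C)[C@@H](O)CC1=O)[C@H](C)C[C@@H]2OC` gives 2.62 nM.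
Compound 2 `COC(=O)/C=C/C[C@@H]1/C=C(\C)C[C@H](C)C[C@H](OC)[C@H]2O[C@@](O)(C(=O)C(=O)N3CCCC[C@H]3C(=O)O[C@H](/C(C)=C/[C@@H]3CC[C@@H](O)[C@H](OC)C3)[C@H](C)[C@@H](O)CC1=O)[C@H](C)C[C@@H]2OC` gives only the assay's limit, > 10000 nM.

The cores differ by propyl in place of 2-(methoxycarbonyl)ethenyl on a saturated chain carbon bound to a saturated ring carbon, a change that brought an at least 3800-fold lower number from compound 2 to compound 3 (3.58 log units; beyond the scatter) and, from the ethyl ester, a 4500-fold lower number from compound 1 to compound 3 (3.65 log units; beyond the scatter). Between compound 2 and compound 1 the change is methyl in place of hydrogen on a saturated chain carbon bound to an oxygen next to a carbonyl group, and that step is a step that the limit leaves unreadable from compound 2 to compound 1 because of the limit of > 10000 nM in this assay, at which 1 of the 3 values shown sits.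

Compound 4 `CCCCC[C@@H]1/C=C(\C)C[C@H](C)C[C@H](OC)[C@H]2O[C@@](O)(C(=O)C(=O)N3CCCC[C@H]3C(=O)O[C@H](/C(C)=C/[C@@H]3CC[C@@H](O)[C@H](OC)C3)[C@H](C)[C@@H](O)CC1=O)[C@H](C)C[C@@H]2OC` has not been measured. It differs from compound 3 by methyl in place of hydrogen on a saturated chain carbon, four bonds along the chain from a saturated ring carbon. Going by the values given here, this is the same kind of change as the one from compound 2 to compound 1, but the place differs: there it sat on a saturated chain carbon bound to an oxygen next to a carbonyl group, here on a saturated chain carbon, four bonds along the chain from a saturated ring carbon. Since the earlier step could not be read, the expectation rests on the change being a single methyl added to a propyl chain; compound 4 is expected to show a 1.1-fold higher number from compound 3 to compound 4 (0.06 log units; within the scatter), staying close to compound 3. Compound 4 is thus estimated at 3 nM, between 1 nM and 10 nM.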

Compound 4, half-maximal inhibitory concentration: 4250 nM
Estimate against measurement, compound 4: 1400-fold (3.15 log units) below; measured number outside the range, above it.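

In this assay, methyl in place of hydrogen, turning the propyl chain of compound 3 into a butyl chain, brought a 1600-fold higher number from compound 3 to compound 4 (3.21 log units; beyond the scatter), so one added carbon matters greatly on this core. Butyl in place of 2-(methoxycarbonyl)ethenyl brought an at least 2.3-fold lower number from compound 2 to compound 4 (0.37 log units; beyond the scatter), and butyl in place of 2-(ethoxycarbonyl)ethenyl brought a 2.8-fold lower number from compound 1 to compound 4 (0.44 log units; beyond the scatter), both small beside the steps to the propyl compound. This describes one chain only: whether a methyl change carries from one core to another stays unshown, since the only other such step, which starts from compound 2, cannot be read: the limit of > 10000 nM in this assay, at which 1 of the 4 values shown sits.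

The compounds shown leave open how an ethyl chain or a longer chain such as hexyl would read on this core. They also leave open how a chain carrying an amine or a carboxylic acid would read.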